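Substituent swaps on a shared core: antiproliferative notes

The compounds below may be only part of what the source reports. "The series", "measured", "known", "first", "only" and "open" are said of these compounds alone.

Three compounds share one core and differ only in the group on an aromatic carbon of the five-membered ring. Compound 1 `O=C1O[C@H]([C@@H](O)Cn2cc(-c3cccc(O)c3)nn2)C(OCc2ccccc2)=C1OCc1ccccc1` gives 54100 nM in a functional assay on CFPAC-1 cells (Homo sapiens) for antiproliferative activity, read by MTT assay, with a stated time of 72 h; a higher number here means a weaker inhibitor, a lower number a stronger inhibitor. Compound 2 `CCCCc1cn(C[C@H](O)[C@H]2OC(=O)C(OCc3ccccc3)=C2OCc2ccccc2)nn1` gives 73200 nM in this assay, and compound 3 `O=C1O[C@H]([C@@H](O)Cn2cc(C3CC3)nn2)C(OCc2ccccc2)=C1OCc1ccccc1` gives 47700 nM. Compound 3 has the smallest number of the three, though every step to it lies within the scatter: a 1.1-fold lower number from compound 1 to compound 3 (0.05 log units; within the scatter), a 1.5-fold lower number from compound 2 to compound 3 (0.19 log units; within the scatter), and likewise a 1.4-fold higher number from compound 1 to compound 2 (0.13 log units; within the scatter). Compound 4 `Cc1ccc(-c2cn(C[C@H](O)[C@H]3OC(=O)C(OCc4ccccc4)=C3OCc3ccccc3)nn2)cc1` is not yet measured; it differs from compound 3 in one place: 4-methylphenyl in place of cyclopropyl on an aromatic carbon. The step from compound 1 to compound 3 already exchanged an aromatic ring for cyclopropyl with no shift beyond the scatter, and the butyl-bearing compound 2 gives the same picture, so another aromatic ring entering there is expected to leave this assay essentially unchanged, with an expected step of a 1.0-fold higher number from compound 3 to compound 4 (0.02 log units; within the scatter). Compound 4 is therefore estimated at 50000 nM, in the range 25000 nM to 100000 nM.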

Compound 4, half-maximal inhibitory concentration: > 100000 nM
Compound 4 gave a limit, no number; the forecaster's own chance of this, stated with the estimate: 10%; middle value at least 2.0-fold (0.30 log units) away from the limit.
By their numbers in this assay, from the lowest: compounds 3, 1 and 2 (each within the scatter of the next). At a limit, above all of these: compound 4.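

Compound 4 is read only as a limit of the assay, not as a number: the limit of > 100000 nM in this assay, at which 1 of the 4 values shown sits. This position is therefore not indifferent to every exchange: the steps among 3-hydroxyphenyl, butyl and cyclopropyl all stayed within the scatter, whereas 4-methylphenyl in place of cyclopropyl gives an at least 2.0-fold higher number from compound 3 to compound 4 (0.32 log units; beyond the scatter), a modest shift that is the only one here beyond the scatter. The other two floors, an at least 1.3-fold higher number from compound 2 to compound 4 (0.13 log units; that floor lies within the scatter) and an at least 1.8-fold higher number from compound 1 to compound 4 (0.26 log units; that floor lies within the scatter), lie within the scatter, so the separation is established only against cyclopropyl, not against butyl or 3-hydroxyphenyl.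

The compounds shown leave open how much of this step belongs to the ring and how much to its methyl group, as a plain phenyl group is absent from the set. Also open, as far as these compounds go, is how an amine, a carboxylic acid or a chain longer than butyl would read at this position.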